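Fluoro for methyl on the benzyl group of compound 2

The source may hold more compounds than are shown below. What is called first, only, known or untested is meant among the compounds shown, and "the series" means these compounds.

Among the compounds with values here, compound 2 `COc1ccc([C@@H]2C/C(=N\O)c3c(O)cc(OCc4cn(Cc5ccccc5C)nn4)cc3O2)cc1O` holds the higher of the two numbers measured so far: in a functional assay on RAW264.7 cells (Mus musculus) for inhibition, read by Griess assay, with stated times of 2 h and 24 h (a lower number here means a stronger inhibitor, a higher number a weaker inhibitor), compound 2 gives 18000 nM, while compound 1 `CCn1cc(COc2cc(O)c3c(c2)O[C@H](c2ccc(OC)c(O)c2)C/C3=N\O)nn1` gives 3140 nM. Within the data shown here, the one measured step, a 5.7-fold higher number from compound 1 to compound 2 (0.76 log units; beyond the scatter), introduces the 2-methylbenzyl group in place of the ethyl group on the triazole nitrogen.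

Compound 3 `COc1ccc([C@@H]2C/C(=N\O)c3c(O)cc(OCc4cn(Cc5ccccc5F)nn4)cc3O2)cc1O` keeps that benzyl group and differs from compound 2 only by fluoro in place of methyl on an aromatic carbon. Among the measured compounds shown here, no measured step changes a substituent on this ring; the step from compound 1 to compound 2 concerns a different change and so bears on it only indirectly. For an exchange of two small groups at the same place on the same ring, a step within the scatter is expected in this assay, with no direction favoured.

Compound 3 is therefore estimated at 15000 nM (range 6000 nM to 40000 nM), the expected step being a 1.2-fold lower number from compound 2 to compound 3 (0.08 log units; within the scatter).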

Compound 3, half-maximal inhibitory concentration: 5710 nM
Compound 3: middle estimate off by 2.6-fold (0.42 log units), on the high side; measured number outside the range, below it.
By their numbers in this assay, from the lowest: compounds 1 and 3 (each within the scatter of the next); then compound 2.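

In this assay, the substituent on the benzyl ring matters: fluoro in place of methyl, a swap of one heavy atom ortho to a large group, gives a 3.2-fold lower number from compound 2 to compound 3 (0.50 log units; beyond the scatter). The benzyl group as such therefore does not carry the rise seen in a 5.7-fold higher number from compound 1 to compound 2 (0.76 log units; beyond the scatter), since a 1.8-fold higher number from compound 1 to compound 3 (0.26 log units; within the scatter) leaves the ethyl and 2-fluorobenzyl groups indistinguishable in this read-out. Nothing measured here accounts for the gap between the fluoro and methyl groups.

Where an unsubstituted benzyl group or a 2-chlorobenzyl group would fall relative to compound 2 and compound 3 remains open. With a single pair on this ring, no trend across substituents can be stated, and a methoxy group or an amine at the same place could follow either compound.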